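Moving the fluorine on the benzyl arm of compound 3

The compounds below may be only part of what the source reports. "The series", "measured", "known", "first", "only" and "open" are said of these compounds alone.

Compound 3 `N#Cc1cccc(COc2ccc(-c3cc(CN4CCN(Cc5ccccc5F)CC4)no3)cc2)c1` gives 2400 nM in a functional assay on Huh-7 cells (Homo sapiens) for antiproliferative activity, read by sulforhodamine B assay, with a stated time of 72 h (a lower number here means a stronger inhibitor, a higher number a weaker inhibitor), the highest of the three numbers measured. Compound 2 `N#Cc1cccc(COc2ccc(-c3cc(CN4CCN(c5ccc(C(F)(F)F)cc5)CC4)no3)cc2)c1` gives 2200 nM, and a 1.1-fold higher number from compound 2 to compound 3 (0.04 log units; within the scatter). Compound 1 `N#Cc1cccc(COc2ccc(-c3cc(CN4CCN(Cc5ccc(C(F)(F)F)cc5)CC4)no3)cc2)c1` gives 100 nM, so that a 24-fold higher number from compound 1 to compound 3 (1.38 log units; beyond the scatter) and a 22-fold higher number from compound 1 to compound 2 (1.34 log units; beyond the scatter).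

Compound 4 `N#Cc1cccc(COc2ccc(-c3cc(CN4CCN(Cc5cccc(F)c5)CC4)no3)cc2)c1` differs from compound 3 in one place: 3-fluorophenyl in place of 2-fluorophenyl on a saturated chain carbon bound to an amine nitrogen in a ring. Within the data shown here, no measured step changes only the position of a substituent on this benzyl ring. The step from compound 1 to compound 3 moves the substituent and exchanges it at the same time, and the step from compound 1 to compound 2 removes the chain carbon, so neither separates the position change from the rest. The one lesson available is that the 4-(trifluoromethyl)benzyl of compound 1 stands far apart from the 2-fluorobenzyl of compound 3, as a 24-fold higher number from compound 1 to compound 3 (1.38 log units; beyond the scatter) shows.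

Compound 4 is therefore expected to land close to compound 3, with wide uncertainty, at an estimated 1500 nM (range 500 nM to 4500 nM), that is a 1.6-fold lower number from compound 3 to compound 4 (0.20 log units; within the scatter).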

Compound 4, half-maximal inhibitory concentration: 2700 nM
For compound 4 the middle estimate is 1.8-fold (0.26 log units) below the measured one; the measured number falls inside the stated range.
By their numbers in this assay, from the lowest: compound 1; then compounds 2, 3 and 4 (each within the scatter of the next).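

Shifting the fluorine from the 2-fluorobenzyl to the 3-fluorobenzyl in this assay gives a 1.1-fold higher number from compound 3 to compound 4 (0.05 log units; within the scatter) and is the first step here that changes position alone, so at this place the two fluorobenzyl arms cannot be told apart. Compound 4 also cannot be told apart from the compound with the 4-(trifluoromethyl)phenyl, with a 1.2-fold higher number from compound 2 to compound 4 (0.09 log units; within the scatter) as the step, whereas a 27-fold higher number from compound 1 to compound 4 (1.43 log units; beyond the scatter) sets the 4-(trifluoromethyl)benzyl of compound 1 apart from the 3-fluorobenzyl as well as from the 2-fluorobenzyl. No measurement shown here offers an explanation for this pattern.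

The compounds shown leave open whether the gap to compound 1 follows from the trifluoromethyl group itself or from where it stands on the benzyl ring. They also leave open how a chlorine or a methoxy group would fare in place of the fluorine on this arm.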